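The compounds below may be only part of what the source reports. "The series", "measured", "known", "first", "only" and "open" are said of these compounds alone.

Measured compounds:
- compound 1 `COc1cc(SC)nc(NC(=S)NC(=O)c2c(-c3ccc(Cl)cc3Cl)noc2C)n1`: in a functional assay on the whole organism for inhibition, with Digitaria ciliaris as the target, with a stated time of 72 h, tested at 100 mg/L (a lower number here means less inhibition of growth, a higher number more inhibition of growth at the concentration tested), compound 1 gives 55.6%
- compound 2 `CSc1cc(C)nc(NC(=S)NC(=O)c2c(-c3ccc(Cl)cc3Cl)noc2C)n1`: compound 2 gives 45.5%
- compound 3 `COc1cc(OC)n2s/c(=N\C(=O)c3c(-c4ccc(Cl)cc4Cl)noc3C)nc2n1`: compound 3 gives 85.3%

Compound 3 stands highest of the three numbers; its nearest neighbour is compound 1, and compound 2 is furthest, both gaps lying beyond the scatter. Compound 4 `COc1cc(SC)nc2n/c(=N/C(=O)c3c(-c4ccc(Cl)cc4Cl)noc3C)sn12` differs from compound 3 in one place: methylsulfanyl in place of methoxy on an aromatic carbon.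

Among the compounds with values here, no measured step swaps exactly these two groups. Within the data shown here, the only single-place step known, a number 10.1 percentage points lower from compound 1 to compound 2 (beyond the scatter), replaced a methoxy group with a methyl group and cost a modest amount of inhibition. Compound 4 also carries the same two ring substituents as compound 1, whose value sits well under that of compound 3, but compound 1 lacks the fused ring and so shows only that the non-fused pattern scores lower. Taken together, a small loss, or none beyond the scatter, is expected: the step of a number 7.3 percentage points lower from compound 3 to compound 4 (within the scatter) is the estimated outcome. Compound 4 is therefore expected to give 78% in this assay, within a range from 62% to 92%.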

Compound 4, percent growth inhibition at one concentration: 79.6%
For compound 4 the middle estimate is 1.6 percentage points below the measured one; the measured number falls inside the stated range.
By their numbers in this assay, from the lowest: compound 2; then compound 1; then compounds 4 and 3 (each within the scatter of the next).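

At this position, on an aromatic carbon of the six-membered aromatic ring with 2 nitrogen, the exchange of methoxy for methylsulfanyl gives a number 5.7 percentage points lower from compound 3 to compound 4 (within the scatter) in this assay and so leaves the read-out unchanged within the usual scatter. Within the data shown here, this is the first direct reading of these two groups against each other, and it shows that oxygen and sulfur as the linking atom cannot be told apart here in this test at one concentration. No measurement at hand explains why the two groups read alike.

Still open, on these data alone, is how far this tolerance reaches, for example with an amine, a chlorine atom or a longer chain such as butoxy at this position. Also open, as far as these compounds go, is whether the same exchange would read alike at the methoxy group that stays in place in compound 4.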